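Amino for chloro: one step, applied a second time

The source may report more compounds than this note shows. Statements on the series, on what has been measured and on what is new or still open speak of the compounds shown alone.

Measured so far:
compound 1 `Nc1nc(Cl)c2ncn(Cc3ccc(CCl)cc3)c2n1`; in a functional assay on U-251 cells (Homo sapiens) for cytotoxicity, read by sulforhodamine B assay, with a stated time of 48 h (a lower number here means a stronger inhibitor of growth, a higher number a weaker inhibitor of growth), compound 1 gives 12000 nM
compound 2 `ClCc1cccc(Cn2cnc3c(Cl)nc(Cl)nc32)c1`; in this assay compound 2 gives 3090 nM
compound 3 `ClCc1ccc(Cn2cnc3c(Cl)nc(Cl)nc32)cc1`; in this assay compound 3 gives 3890 nM

Compound 2 and compound 3 share the same atoms joined differently; the difference between the two cores is not broken down here, and their values lie within the scatter of each other. Compound 1 stands apart: from compound 3 to compound 1 the change amino in place of chloro on an aromatic carbon gave a 3.1-fold higher number from compound 3 to compound 1 (0.49 log units; beyond the scatter) in this assay.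

Compound 4 `Nc1nc(Cl)c2ncn(Cc3cccc(CCl)c3)c2n1` is not yet measured. It differs from compound 2 by amino in place of chloro on an aromatic carbon, the same change as from compound 3 to compound 1, at a place described in the same words. The expectation therefore rests on that one measured step, a 3.1-fold higher number from compound 3 to compound 1 (0.49 log units; beyond the scatter), together with the value of compound 2, 3090 nM. One prior instance is a thin basis, so the range is kept wide. For compound 4 in this assay the estimate is 9500 nM, between 4000 nM and 22000 nM, which is expected to mean a 3.1-fold higher number from compound 2 to compound 4 (0.49 log units; beyond the scatter).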

Compound 4, concentration for total growth inhibition: 4070 nM
Compound 4: the middle estimate sits 2.3-fold (0.37 log units) above what was measured; low and high end bracket the measured number.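

In this assay, amino in place of chloro on an aromatic carbon gave a 1.3-fold higher number from compound 2 to compound 4 (0.12 log units; within the scatter), a step that by itself cannot be told apart from repeat scatter. Set beside the earlier step, the result gives no sign that the two cores respond differently: the same change on two cores in this assay, a 3.1-fold higher number (0.49 log units; beyond the scatter) from compound 3 to compound 1 and a 1.3-fold higher number (0.12 log units; within the scatter) from compound 2 to compound 4, 2.3-fold (0.37 log units) apart, within the scatter of two such steps This permits a single shared step of uncertain size, but two pairs neither establish that the size carries over from core to core nor show a real difference between the cores, and they say nothing of cores outside compounds 1 to 4.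

The compounds shown leave open whether a methoxy or dimethylamino group on that same aromatic carbon would give a step like that of amino. They also leave open how the series responds when the chloromethyl group gives way to a hydroxymethyl group, and whether the amino step then looks the same.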